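This account rests on a few compounds, and the source may have more. Where it says the series, first, only, none or still open, it means among the compounds named here.

Compound 3 `O=C(O)CCn1c(=O)oc2cc(OCc3ccccc3)c(Cl)cc21` gives no reading in a physicochemical assay for permeability, using PAMPA; a lower number here means that the compound crosses the layer more slowly, a higher number that the compound crosses the layer faster: for compound 3 the entry is "not determined" (no result reported). Its position therefore has to be inferred from its neighbours. Compound 1 `COCCOc1cc2oc(=O)n(CCC(=O)O)c2cc1Cl` gives < 3 nm/s, which is a limit of the assay and not a number. Compound 2 `O=C(O)CCn1c(=O)oc2cc(OCC3CCC3)c(Cl)cc21` gives 12 nm/s.

The change to compound 4 `COc1cc2oc(=O)n(CCC(=O)O)c2cc1Cl` is hydrogen in place of phenyl on a saturated chain carbon bound to an oxygen on an aromatic ring. Within the data shown here, one measured step bears on it, at the same place: an at least 4.0-fold higher number from compound 1 to compound 2 (0.60 log units; beyond the scatter), with cyclobutyl in place of methoxymethyl. That step shows that a swap at this carbon can move this assay beyond the scatter. With no number for compound 3, the step to compound 4 cannot be sized directly. A lower number of at least modest size is nonetheless expected, and compound 4 is expected to lie closer to compound 1 than to compound 2. Compound 4 may also read only as a limit, since the series already shows (the limit of < 3 nm/s in this assay, at which 1 of the 3 values shown sits). For compound 4 the estimated value is 4 nm/s, with an expected range of 1.5 nm/s to 12 nm/s.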

Compound 4, apparent permeability: < 3 nm/s
Compound 4 was reported as a limit (the forecaster's own chance of this, stated with the estimate: 45%); middle value at least 1.3-fold (0.12 log units) from the limit.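

Hydrogen in place of cyclobutyl on a saturated chain carbon bound to an oxygen on an aromatic ring gives an at least 4.0-fold lower number from compound 2 to compound 4 (0.60 log units; beyond the scatter) in this assay, so removing the group at this carbon, and not only exchanging it as in the earlier step, moves the read-out beyond the scatter. Compound 4 gives < 3 nm/s, which is a limit of the assay and not a number, so the step has a lower bound on its size but no fixed size. Among these compounds, compound 2 remains the only compound here with a number, while compound 1 and compound 4 share the same limit, and the step between those two cannot be read: the limit of < 3 nm/s in this assay, at which 2 of the 4 values shown sit.

From the compounds shown here alone, with no reading for compound 3, it remains open how phenyl on this carbon compares with cyclobutyl, and whether a carbon-only group is what separates compound 2 from compound 1 and compound 4. A longer saturated carbon chain at this carbon, an amine in that chain, or an amide in place of the carboxylic acid shared by all four compounds would each test how far the read-out can be moved above the limit.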